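Swapping methoxy for chloro on the N-phenyl ring

The compounds below may be only part of what the source reports. "The series", "measured", "known", "first", "only" and "open" are said of these compounds alone.

Three close relatives of one pyrazole dicarboxylate core have been tested in a functional assay on DU-145 cells (Homo sapiens) for cytotoxicity, read by MTT assay, with a stated time of 48 h; on this read-out higher numbers stand for weaker inhibition and lower numbers for stronger inhibition. Compound 1 `CCOC(=O)c1c(-c2c(Cl)c3ccccc3oc2=O)nn(-c2ccc(OC)cc2)c1C(=O)OCC` gives 25000 nM, compound 2 `CCOC(=O)c1c(-c2cc3ccccc3oc2=O)nn(-c2ccc(OC)cc2)c1C(=O)OCC` gives 39000 nM, and compound 3 `COC(=O)c1c(-c2cc3ccccc3oc2=O)nn(-c2cccc(Cl)c2)c1C(=O)OC` gives 32000 nM. Compound 2 holds the highest of the three numbers, yet every gap to it lies within the scatter, so the three cannot be ranked. For the measured compounds named here, the only single-place step, a 1.6-fold higher number from compound 1 to compound 2 (0.19 log units; within the scatter), is also within the scatter. Compound 4 `CCOC(=O)c1c(-c2cc3ccccc3oc2=O)nn(-c2ccc(Cl)cc2)c1C(=O)OCC` differs from compound 2 by chloro in place of methoxy on an aromatic carbon. Going by the values given here, no measured step touches this position, and compound 3 differs in more than one place. Compound 4 is therefore expected to stay near compound 2, a step of a 1.3-fold lower number from compound 2 to compound 4 (0.11 log units; within the scatter), with an estimated value of 30000 nM, between 12000 nM and 75000 nM.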

Compound 4, half-maximal inhibitory concentration: 26000 nM
For compound 4 the middle estimate is 1.2-fold (0.06 log units) above the measured one, and the stated range covers the measured number.
By their numbers in this assay, from the lowest: compounds 1, 4, 3 and 2 (each within the scatter of the next).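

For the compounds shown here, this is the first measured step at this position: in this assay there is a 1.5-fold lower number from compound 2 to compound 4 (0.18 log units; within the scatter) when 4-chlorophenyl replaces 4-methoxyphenyl. So this exchange of methoxy for chloro, which removes a hydrogen-bond acceptor and one heavy atom, leaves the number within the scatter. No measurement offered here bears on why this is so.

From the compounds shown here alone, whether an amine, a carboxylic acid or a longer chain such as butoxy at this place would also stay within the scatter remains open. So does the outcome of the same exchange on compound 1.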